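The source may hold more compounds than are shown below. What is called first, only, known or untested is meant among the compounds shown, and "the series" means these compounds.

Of the compounds shown here, two built on one shared core have so far been measured in an assay on HeLa cells for displacement of a labelled ligand from 5-hydroxytryptamine receptor 6 (Homo sapiens); on this read-out higher numbers stand for weaker inhibition and lower numbers for stronger inhibition. Compound 1 `N=c1c(S(=O)(=O)c2ccccc2)c(NCCO)nc2ccccn12` gives 42 nM in this assay. Compound 2 `CSc1nc2ccc(Cl)cn2c(=N)c1S(=O)(=O)c1ccccc1` gives 28 nM in this assay. These two numbers lie within the scatter of repeated measurements of one another, so neither compound can be called the tighter binder; compound 2 simply carries the smaller of the two numbers in hand, with compound 1 close by. Going by the values given here, the two structures differ in more than one place, so no single step between them is described here.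

Compound 3 `CSc1nc2ccc(C(N)=O)cn2c(=N)c1S(=O)(=O)c1ccccc1` has not yet been measured in this assay. It differs from compound 2 in one place: carbamoyl in place of chloro on an aromatic carbon. Among the compounds with values here, nothing among the measured compounds shows the effect of this exchange. The expectation for compound 3 therefore rests on compound 2 alone, whose value of 28 nM sets the starting point. A small step toward a higher number is expected, a 2.1-fold higher number from compound 2 to compound 3 (0.33 log units; beyond the scatter), one that may or may not exceed the scatter. Compound 3 is estimated at 60 nM in this assay, within a range from 15 nM to 250 nM.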

Compound 3, half-maximal inhibitory concentration: 8.8 nM
Estimate against measurement, compound 3: 6.8-fold (0.83 log units) above; measured number outside the range, below it.
By their numbers in this assay, from the lowest: compound 3; then compounds 2 and 1 (each within the scatter of the next).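

This result shows that the position on the aromatic carbon, two atoms from the ring nitrogen, has a real influence on the read-out: in this assay, exchanging chloro for carbamoyl gives a 3.2-fold lower number from compound 2 to compound 3 (0.50 log units; beyond the scatter) and so moves the value beyond the usual scatter. It also shows that chloro is not required at this position, since a group of three heavy atoms in place of a single chlorine atom goes with stronger inhibition. No measurement shown here explains why the number falls, so the change can be recorded but not attributed to any one feature of the carbamoyl group.

As far as these compounds go, all of this rests on one exchange at one position, made with the methylthio group and the phenylsulfonyl group of compound 2 left in place, so it is open whether the same exchange would have a similar effect alongside other groups. From the compounds shown here alone, it is also open which part of the carbamoyl group matters, a question that a nitrile, a carboxylic acid or an N-methyl carboxamide at the same position could begin to answer.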